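The source may hold more compounds than are shown below. What is called first, only, known or untested is meant among the compounds shown, and "the series" means these compounds.

Compound 1 `CC(C)Oc1ccc(C(O)(c2ccc(Cl)cc2)c2cccnc2)cc1`: 56600 nM
Compound 2 `CC(C)Oc1ccc(C(O)(c2ccc(C(F)(F)F)cc2)c2cccnc2)cc1`: 47600 nM
Compound 3 `OC(c1ccc(Cl)cc1)(c1cccnc1)c1ccccc1Br`: 55200 nM

In an ADME assay on L6 cells (Rattus norvegicus) for cytotoxicity, read by resazurin assay, with a stated time of 72 h (a higher number here means a weaker inhibitor, a lower number a stronger inhibitor), compound 2 stands level with compound 1 and compound 3, all three values lying within the scatter of one another. Compound 4 `CN(C)c1ccc(C(O)(c2ccc(C(F)(F)F)cc2)c2cccnc2)cc1` differs from compound 2 by dimethylamino in place of isopropoxy on an aromatic carbon. Going by the values given here, no measured step covers this change. The only one, a 1.2-fold lower number from compound 1 to compound 2 (0.08 log units; within the scatter), is a different change, trifluoromethyl in place of chloro, and it stays within the scatter. Compound 3 carries no isopropoxy and still gives 55200 nM. The expected result is a 1.1-fold lower number from compound 2 to compound 4 (0.05 log units; within the scatter), which would be no step beyond the scatter. Compound 4 is estimated at 42000 nM, with an expected range of 18000 nM to 90000 nM.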

Compound 4, half-maximal inhibitory concentration: 59100 nM
For compound 4 the middle estimate is 1.4-fold (0.15 log units) below the measured one; the measured number falls inside the stated range.
By their numbers in this assay, from the lowest: compounds 2, 3, 1 and 4 (each within the scatter of the next).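

In this assay, going by these compounds alone, dimethylamino in place of isopropoxy, on an aromatic carbon para to a large group, gives a 1.2-fold higher number from compound 2 to compound 4 (0.09 log units; within the scatter) and so provides the first reading at this position, which stays within the scatter. The earlier step covered only trifluoromethyl in place of chloro elsewhere in the molecule. Nothing at hand bears on this result. Going by these compounds, whether a primary amine, a carboxylic acid or a longer chain at this position would move the number beyond the scatter stays open. So does whether dimethylamino behaves alike with chloro in place of trifluoromethyl.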